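This account rests on a few compounds, and the source may have more. Where it says the series, first, only, none or still open, it means among the compounds named here.

Measured compounds:
compound 1, `CN1C/C(=C\c2ccc(Cl)cc2)C(=O)[C@]2(C1)[C@@H](c1ccc(Cl)cc1)CN(C)[C@@]21C(=O)N(C)c2ccccc21`, 80.9%
compound 2, `Cc1ccc(/C=C2\CN(C)C[C@@]3(C2=O)[C@@H](c2ccc(C)cc2)CN(C)[C@@]32C(=O)Nc3ccccc32)cc1`, 89.7%

Of the compounds shown here, two have been measured in a functional assay on the whole organism (strain Wister albino) for inhibition, with Rattus norvegicus as the target, read by paw edema, with stated times of 1 h and 4 h, at a dose of 50 mg/kg by the intraperitoneal route; a higher number here means more inhibition at the dose given (going by the name of the read-out), a lower number less inhibition. Compound 1 `CN1C/C(=C\c2ccc(Cl)cc2)C(=O)[C@]2(C1)[C@@H](c1ccc(Cl)cc1)CN(C)[C@@]21C(=O)N(C)c2ccccc21` gives 80.9% in this assay. Compound 2 `Cc1ccc(/C=C2\CN(C)C[C@@]3(C2=O)[C@@H](c2ccc(C)cc2)CN(C)[C@@]32C(=O)Nc3ccccc32)cc1` gives 89.7% in this assay, the higher of the two numbers, yet its gap to compound 1 lies within the usual scatter, so the two cannot be told apart. Within the data shown here, the two structures differ in more than one place, so no single step connects them.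

Compound 3 `Cc1ccc(/C=C2\CN(C)C[C@@]3(C2=O)[C@@H](c2ccc(C)cc2)CN(C)[C@@]32C(=O)N(C)c3ccccc32)cc1` differs from compound 2 in one place: methyl in place of hydrogen on an amide-type nitrogen in a ring. Compound 1 already carries a methyl on the same amide-type nitrogen while compound 2 does not, and their numbers in this assay sit close together, so no step beyond the scatter is expected here. Compound 3 is expected to give about 86% in this assay, with a range from 72% to 95%, the expected step being a number 3.7 percentage points lower from compound 2 to compound 3 (within the scatter).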

Compound 3, a percentage reported as inhibition, in the whole organism at one dose (the size of the read-out at that dose, not a potency): 122%
Compound 3: the middle estimate sits 36 percentage points below what was measured, outside the stated range (above it).
By their numbers in this assay, from the lowest: compounds 1 and 2 (each within the scatter of the next); then compound 3.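

Going from hydrogen to methyl on the amide-type nitrogen in a ring gives a number 32.3 percentage points higher from compound 2 to compound 3 (beyond the scatter) in this assay. This shows that the read-out at the given dose can respond strongly to a single added carbon at this position, with all else in the structure held the same. Compounds 1 and 2 differ in more than one place, so they could not isolate this nitrogen, and no measurement shown here bears on why the step arises.

The compounds shown leave open whether an ethyl group, a longer chain or a chain ending in a carboxylic acid on this nitrogen would keep, lose or extend the step. They also leave open whether the same change would give a similar step with the chlorine-bearing rings of compound 1 in place of the methyl-bearing ones.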